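The compounds below may be only part of what the source reports. "The series", "measured", "known", "first", "only" and "open" are said of these compounds alone.

In a functional assay on U-251 cells (Homo sapiens) for inhibition, read by sulforhodamine B assay, with a stated time of 72 h (on this read-out higher numbers stand for an effect only at larger amounts of compound and lower numbers for an effect already at smaller amounts), two compounds have been measured so far:

compound 1 `CCCCc1ccc(C(=O)/C=C/c2ccc([N+](=O)[O-])o2)cc1`: 3900 nM
compound 2 `CC(C)(C)c1ccc(C(=O)/C=C/c2ccco2)cc1`: 16400 nM

Compound 2 has the higher of the two numbers, and its gap to compound 1 lies beyond the usual scatter. Compound 3 `CCCCc1ccc(C(=O)/C=C/c2ccco2)cc1` differs from compound 2 by a single swap: butyl in place of tert-butyl on an aromatic carbon. Within the data shown here, no measured pair shows this swap on its own, so the data offer no direct guide to its size. In this assay, a small step towards a lower number is expected, probably none beyond the scatter. The estimated change is a 1.3-fold lower number from compound 2 to compound 3 (0.10 log units; within the scatter). The estimate for compound 3 is 13000 nM, with an expected range of 5500 nM to 30000 nM.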

Compound 3, half-maximal effective concentration: 6400 nM
Estimate against measurement, compound 3: 2.0-fold (0.31 log units) above, within the range that was stated.
By their numbers in this assay, from the lowest: compounds 1 and 3 (each within the scatter of the next); then compound 2.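

In this assay, the arrangement of the same atoms at this place on the ring makes a measurable difference: butyl in place of tert-butyl gives a 2.6-fold lower number from compound 2 to compound 3 (0.41 log units; beyond the scatter) in this series. Hydrogen in place of nitro on the other ring gives a 1.6-fold higher number from compound 1 to compound 3 (0.22 log units; within the scatter) and so shows no clear effect of the nitro group on this butyl compound. No measurement here explains either result.

On these data alone, whether a longer chain such as hexyl would lower the number further remains open. So does the effect of an amine at this place.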